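The source may report more compounds than this note shows. Statements on the series, on what has been measured and on what is new or still open speak of the compounds shown alone.

In an ADME assay on cells (Hepatocyte, Mus musculus) for cytotoxicity, read by MTT assay, with a stated time of 24 h (a lower number here means that less compound is tolerated, a higher number that more compound is tolerated), compound 1 (`FC(F)(F)c1ccc(-c2nn(-c3ccccc3)cc2-c2nc3ccccc3[nH]2)cc1`) gives 159000 nM while compound 2 (`O=S(=O)(c1ccc(Cl)cc1)n1c(-c2cn(-c3ccccc3)nc2-c2ccc(F)cc2)nc2ccccc21`) gives 231000 nM and compound 3 (`Cc1ccc(C)c(S(=O)(=O)n2c(-c3cn(-c4ccccc4)nc3-c3ccc(C(F)(F)F)cc3)nc3ccccc32)c1`) gives 132000 nM as its measured concentration. Compound 3 lies within the scatter of both compound 1 and compound 2. Compound 4 (`O=S(=O)(c1ccc(Cl)cc1)n1c(-c2cn(-c3ccccc3)nc2-c2ccc(C(F)(F)F)cc2)nc2ccccc21`) has not yet been measured. It carries 4-chlorophenyl in place of 2,5-dimethylphenyl on a sulfonyl sulfur whose other neighbour is an aromatic nitrogen (4-chlorophenyl in place of 2,5-dimethylphenyl on a sulfonyl sulfur). For the measured compounds named here, the only measured step at this place is a 1.2-fold lower number from compound 1 to compound 3 (0.08 log units; within the scatter) and it stays within the scatter, even though it adds the whole (2,5-dimethylphenyl)sulfonyl group. The same (4-chlorophenyl)sulfonyl group as in compound 4 is carried by compound 2, which gives 231000 nM in spite of a difference elsewhere in the structure. No step beyond the scatter is therefore expected in this assay from this exchange, and no firm direction can be assigned. The estimated change is a 1.3-fold higher number from compound 3 to compound 4 (0.11 log units; within the scatter) and would remain inside the scatter. Compound 4 is expected at 170000 nM with 95000 nM to 300000 nM as the estimated range.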

Compound 4, half-maximal cytotoxic concentration: 173000 nM
Estimate against measurement, compound 4: 1.0-fold (0.01 log units) below; low and high end bracket the measured number.
By their numbers in this assay, from the lowest: compounds 3, 1, 4 and 2 (each within the scatter of the next).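

In this assay, the exchange of 2,5-dimethylphenyl for 4-chlorophenyl on the sulfonyl sulfur now has a direct reading (a 1.3-fold higher number from compound 3 to compound 4 (0.12 log units; within the scatter)). Placing (4-chlorophenyl)sulfonyl in place of hydrogen on the aromatic nitrogen also stays within the scatter (a 1.1-fold higher number from compound 1 to compound 4 (0.04 log units; within the scatter)), so two different sulfonyl groups at this place now show no step beyond it. A second place gets its first reading as well, since trifluoromethyl in place of fluoro on an aromatic carbon also remains within the scatter (a 1.3-fold lower number from compound 2 to compound 4 (0.13 log units; within the scatter)).

Nothing available speaks to why these numbers stay so close together. Going by these compounds, whether a sulfonyl group carrying an amine or a carboxylic acid on its ring, or a longer alkyl chain in place of that ring, would give a step beyond the scatter remains open.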